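Swapping the Pyridinylmethyl Amide for a Benzyl Carbamate

The source may hold more compounds than are shown below. What is called first, only, known or untested is meant among the compounds shown, and "the series" means these compounds.

Compound 1 `Cc1cc(C(=O)NCc2ccccn2)nn1Cc1cc(Cl)ccc1OCc1ccccc1`: > 3.7
Compound 2 `Cc1cc(NC(=O)C2CCCC2)nn1Cc1cc(Cl)ccc1OCC(C)C`: > 3.7

Both measured compounds were examined in a physicochemical assay for lipophilicity, at pH 7.4; a higher number here means a more lipophilic compound, a lower number a more polar compound. For compound 1 the read-out is a limit of the assay, not a number: > 3.7. For compound 2 the read-out is likewise only a limit: > 3.7. Compound 1 therefore stands at the limit of > 3.7 in this assay, at which 2 of the 2 values shown sit, and the numbers shown do not separate it from compound 2. Within the data shown here, no pair of measured compounds differing in a single place exists, so no measured step is available to guide the next move.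

Compound 3 `Cc1cc(NC(=O)OCc2ccccc2)nn1Cc1cc(Cl)ccc1OCc1ccccc1` is the next candidate and has not yet been measured. It differs from compound 1 in one place: (benzyloxycarbonyl)amino in place of ((pyridin-2-yl)methyl)carbamoyl on an aromatic carbon. Because both measured values sit at the limit of > 3.7 in this assay, at which 2 of the 2 values shown sit, the true distance of this change cannot be read from them. The expectation is a step that the limit leaves unreadable from compound 1 to compound 3, a small shift upward rather than none. Compound 3 is expected to give 4.3, with a likely span from 3.7 to 5, and most probably the assay will again report only a limit.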

Compound 3, distribution coefficient: 3.1
The estimate for compound 3 lay 1.20 log units above the measured number; the whole stated range lies above it.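

In this assay compound 1 gives > 3.7, which is a limit of the assay and not a number. Among these compounds, compound 3 gives 3.1, the first true number at this aromatic carbon of the five-membered ring, and putting (benzyloxycarbonyl)amino in place of ((pyridin-2-yl)methyl)carbamoyl gives a number at least 0.60 log units lower from compound 1 to compound 3 (beyond the scatter), even though the two groups have the same counts of hydrogen-bond donors and acceptors and the entering group has a ring of carbon only. The real size of this step stays unknown, and only its minimum can be stated, because the starting point is a limit: the limit of > 3.7 in this assay, at which 2 of the 3 values shown sit.

The change alters the ring and the chain that links it to the core together, so the compounds shown cannot assign the step to either part alone. From the compounds shown here alone, it also remains open what a simple amine or a carboxylic acid on the same aromatic carbon would give in this assay, and whether a longer chain between the carbonyl and the benzene ring would move the value again.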